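Replacing phenyl on a compound at the assay limit

The source may hold more compounds than are shown below. What is called first, only, known or untested is meant among the compounds shown, and "the series" means these compounds.

Among the compounds with values here, in a functional assay on SMMC-7721 cells (Homo sapiens) for inhibition, read by MTT assay, with a stated time of 48 h (on this read-out lower numbers stand for stronger inhibition and higher numbers for weaker inhibition), compound 1 `CN(c1ncccc1CNc1nc(Nc2ccc3c(c2)CC(=O)N3)nc2[nH]cc(Cl)c12)S(C)(=O)=O` gives 21900 nM as the only true number so far. Compound 2 `CN(c1ncccc1CNc1nc(Nc2ccccc2)nc2[nH]cc(F)c12)S(C)(=O)=O` gives > 100000 nM as its result, which is a limit of the assay and not a number. Compound 3 `COc1cccc(Nc2nc(NCc3cccnc3N(C)S(C)(=O)=O)c3c(F)c[nH]c3n2)c1C` carries 3-methoxy-2-methylphenyl in place of phenyl on a nitrogen on an aromatic ring and otherwise matches compound 2. Within the data shown here, no measured pair isolates this change, so the expectation is only loosely anchored. Among the measured compounds shown here, the one numeric reference is compound 1 at 21900 nM in this assay and serves as a rough guide. The expected step of an at least 2.0-fold lower number from compound 2 to compound 3 (0.30 log units; that floor lies within the scatter) is modest and toward stronger inhibition, and a result at the limit again remains possible. Compound 3 is estimated at 50000 nM with an expected range from 15000 nM to 100000 nM in this read-out.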

Compound 3, half-maximal inhibitory concentration: > 100000 nM
Compound 3: a limit, no number; the forecaster's own chance of this, stated with the estimate: 35%; middle value at least 2.0-fold (0.30 log units) from the limit.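

Compound 2 and compound 3 each give a limit and not a number in this assay, so no step can be read between them: the limit of > 100000 nM in this assay, at which 2 of the 3 values shown sit.

The compounds shown leave open whether 3-methoxy-2-methylphenyl in place of phenyl on a nitrogen on an aromatic ring changes inhibition at all.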